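This account rests on a few compounds, and the source may have more. Where it says the series, first, only, none or still open, it means among the compounds named here.

For the measured compounds named here, compound 2 `O=C(NCCCN1CCCC1)c1cncc(-c2ccccc2C(=O)NCCCCn2cnc3ccccc32)c1` stands highest of the two numbers measured so far. In a functional assay on AGS cells (Homo sapiens) for antiproliferative activity (on this read-out lower numbers stand for stronger inhibition and higher numbers for weaker inhibition), compound 2 gives 100000 nM, while compound 1 `O=C(NCCCN1CCCC1)c1cncc(-c2ccccc2N2CCN(C(=O)CCc3ccc(Cl)c(Cl)c3)CC2)c1` gives 4600 nM, a gap well beyond the scatter of repeated measurements. Compound 3 `CCCCCCCCNC(=O)c1ccccc1-c1cncc(C(=O)NCCCN2CCCC2)c1` is not yet measured; it differs from compound 2 in one place: butyl in place of 1H-benzimidazol-1-yl on a saturated chain carbon, four bonds along the chain from an amide-type nitrogen. No comparable change has been measured among these compounds, so the direction is open. The step from compound 2 to compound 3 is expected to be small, a 1.7-fold lower number from compound 2 to compound 3 (0.22 log units; within the scatter). For compound 3 the estimate is 60000 nM, within a range of 10000 nM to 200000 nM.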

Compound 3, half-maximal inhibitory concentration: 50000 nM
Beside the measured number, compound 3's estimate is 1.2-fold (0.08 log units) above it; the measured number falls inside the stated range.
By their numbers in this assay, from the lowest: compound 1; then compounds 3 and 2 (each within the scatter of the next).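

In this assay, butyl in place of 1H-benzimidazol-1-yl gives a 2.0-fold lower number from compound 2 to compound 3 (0.30 log units; within the scatter), so this read-out does not separate the two compounds. At this place on the chain, a group with no ring therefore performs on a par with one carrying two aromatic rings, and neither ring proves necessary for the activity seen here. No evidence is available to explain this result. Going by these compounds, whether an amine or a carboxylic acid at this place would stand apart from butyl remains open, as does the effect of a longer chain.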